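This account rests on a few compounds, and the source may have more. Where it says the series, first, only, none or still open, it means among the compounds named here.

Measured compounds:
Compound 1, `CSc1nc(NCc2ccc(-c3ccccn3)cc2)c2[nH]nc(C(C)C)c2n1`, gives 778 nM in a functional assay on K562 cells (Homo sapiens) for cytotoxicity, read by fluorescence, with a stated time of 72 h; a lower number here means a stronger inhibitor, a higher number a weaker inhibitor.
Compound 2, `CC(C)c1n[nH]c2c(NCc3ccc(-c4ccccn4)cc3)nc(NCCO)nc12`, gives 38 nM in this assay.

Compound 1 stands with the highest of the two numbers; its nearest neighbour is compound 2, and the step of a 20-fold lower number from compound 1 to compound 2 (1.31 log units; beyond the scatter) lies beyond the scatter. Compound 3, `COc1ccc(CNc2nc(NCc3ccc(-c4ccccn4)cc3)c3[nH]nc(C(C)C)c3n2)cc1`, has not yet been measured in this assay. It differs from compound 1 in one place: (4-methoxybenzyl)amino in place of methylsulfanyl on an aromatic carbon. Within the data shown here, the one measured step that bears on this change is a 20-fold lower number from compound 1 to compound 2 (1.31 log units; beyond the scatter), where an amino group likewise took the place of methylsulfanyl at the same carbon. That step was large and lowered the number. The new group is a different amino substituent, so the size of the gain is uncertain, but a lower number is expected. Compound 3 is therefore estimated at 100 nM, with a range from 30 nM to 400 nM, which means an expected step of a 7.8-fold lower number from compound 1 to compound 3 (0.89 log units; beyond the scatter).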

Compound 3, half-maximal inhibitory concentration: 3950 nM
The estimate for compound 3 lay 40-fold (1.60 log units) below the measured number; the measured number lies above the stated range.
By their numbers in this assay, from the lowest: compound 2; then compound 1; then compound 3.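

In this assay, an amino link at this carbon, between two ring nitrogen atoms, does not by itself lower the number: (4-methoxybenzyl)amino in place of methylsulfanyl gives a 5.1-fold higher number from compound 1 to compound 3 (0.71 log units; beyond the scatter), the opposite direction to a 20-fold lower number from compound 1 to compound 2 (1.31 log units; beyond the scatter). The outcome therefore depends on what the amino nitrogen carries, since 4-methoxyphenyl in place of hydroxymethyl on the chain gives a 100-fold higher number from compound 2 to compound 3 (2.02 log units; beyond the scatter), a far larger step than either change from methylsulfanyl. Nothing measured here accounts for this gap.

The compounds shown leave open whether the higher number of compound 3 goes with its aromatic ring or with the methoxy group on that ring, and where a plain benzylamino group would fall. They also leave open whether the hydroxyl of compound 2 matters, a question that an ethylamino or a 3-hydroxypropylamino group would bear on.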